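Replacing benzyl with 3-bromophenyl: what compound 4 may show

The compounds below may be only part of what the source reports. "The series", "measured", "known", "first", "only" and "open" are said of these compounds alone.

In a functional assay on HT-29 cells (Homo sapiens) for antiproliferative activity, read by sulforhodamine B assay, with a stated time of 72 h (a lower number here means a stronger inhibitor, a higher number a weaker inhibitor), compound 3 `S=C(NCc1ccccc1)N/N=C/c1ccc2ccccc2n1` gives 75700 nM as the higher of the two actual numbers, and compound 2 `N#Cc1ccc(NC(=S)N/N=C/c2ccc3ccccc3n2)cc1` gives 15600 nM as the lower. Compound 1 `Fc1ccccc1NC(=S)N/N=C/c1ccc2ccccc2n1` gives > 100000 nM as a limit of the assay and not a number. Compound 4 `S=C(N/N=C/c1ccc2ccccc2n1)Nc1cccc(Br)c1` carries 3-bromophenyl in place of benzyl on an amide-type nitrogen. The closest guide, read in reverse, is the step of a 4.9-fold higher number from compound 2 to compound 3 (0.69 log units; beyond the scatter) when benzyl takes the place of 4-cyanophenyl. The 2-fluorophenyl group gives no such gain, with the step of an at least 1.3-fold lower number from compound 1 to compound 3 (0.12 log units; that floor lies within the scatter) when benzyl enters, and the step of an at least 6.4-fold lower number from compound 1 to compound 2 (0.80 log units; beyond the scatter) shows how far these groups can differ. In this assay the expected step is therefore a 2.5-fold lower number from compound 3 to compound 4 (0.40 log units; beyond the scatter) with a wide margin either way. Compound 4 is estimated at 30000 nM (range 8000 nM to 100000 nM).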

Compound 4, half-maximal inhibitory concentration: 58900 nM
The estimate for compound 4 lay 2.0-fold (0.29 log units) below the measured number, within the range that was stated.
By their numbers in this assay, from the lowest: compound 2; then compounds 4 and 3 (each within the scatter of the next). At a limit, above all of these: compound 1.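

In this assay, benzyl and 3-bromophenyl on this amide-type nitrogen are not told apart, with a 1.3-fold lower number from compound 3 to compound 4 (0.11 log units; within the scatter). 4-Cyanophenyl stays clear of 3-bromophenyl, with a 3.8-fold higher number from compound 2 to compound 4 (0.58 log units; beyond the scatter), so a substituted phenyl group here does not by itself give the lower number. The step of an at least 1.6-fold lower number from compound 1 to compound 4 (0.22 log units; that floor lies within the scatter) is only a floor, set by a limit of the assay and not a number: the limit of > 100000 nM in this assay, at which 1 of the 4 values shown sits.

On these data alone, it remains open whether the lower number of 4-cyanophenyl depends on the nitrile itself. Also open, as far as these compounds go, is what an amine, a carboxylic acid or a longer chain would give at this nitrogen.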